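The source may hold more compounds than are shown below. What is called first, only, known or untested is meant among the compounds shown, and "the series" means these compounds.

Measured compounds:
Compound 1 `COc1ccc(S(=O)(=O)N(C)CCOCC(=O)N(C)Cc2ccc(C3=NCCN3)cc2)c(C)c1`, which gives 8.6 in a functional assay on Umbilical vein for antagonist activity at B1 bradykinin receptor (Homo sapiens), using Schild analysis, with a stated time of 30 min; a lower number here means a less potent compound, a higher number a more potent compound, by a factor of ten per unit of this negative logarithm.
Compound 2 `COc1cc(C)c(S(=O)(=O)N(C)CCOCC(=O)N2CCC(C(C)(C)CN(C)C)CC2)c(C)c1`, which gives 7.5 in this assay.

Of the two compounds measured, compound 2 gives the lower number in this assay; compound 1 stands higher by a margin beyond the usual scatter of repeated measurements. Compound 3 `COc1cc(C)c(S(=O)(=O)N(C)CCOCC(=O)N2CCC(C(O)CN(C)C)CC2)c(C)c1` has not yet been measured. It differs from compound 2 in one place: 2-(dimethylamino)-1-hydroxyethyl in place of 1-((dimethylamino)methyl)-1-methylethyl on a saturated ring carbon. For the measured compounds named here, no step between two measured compounds involves an exchange of this kind, so the measured pair gives no direct guide to how the numbers respond to it. The expectation is therefore a modest step from compound 2 to compound 3 in this assay, most likely slightly downward or none beyond the scatter a number 0.30 log units lower from compound 2 to compound 3 (within the scatter). Compound 3 is expected to give about 7.2, with a range from 6.4 to 8.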

Compound 3, negative logarithm of the antagonist equilibrium constant: 7.4
Beside the measured number, compound 3's estimate is 0.20 log units below it; low and high end bracket the measured number.
By their numbers in this assay, from the lowest: compounds 3 and 2 (each within the scatter of the next); then compound 1.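

In this assay, putting 2-(dimethylamino)-1-hydroxyethyl in place of 1-((dimethylamino)methyl)-1-methylethyl on the saturated ring carbon gives a number 0.10 log units lower from compound 2 to compound 3 (within the scatter). This position therefore tolerates a change from a group with no hydrogen-bond donor to one that has a hydrogen-bond donor, and from seven heavy atoms to six, with no change in the number that can be told from the scatter. Nothing at hand bears on why the number holds across this exchange.

As far as these compounds go, the exchange alters the hydroxyl and the carbon branching in a single step, so the share of each remains open. Also open, from the compounds shown here alone, is how the number would respond if the dimethylamino group gave way to a pyrrolidine, a primary amine or a carboxylic acid at the end of this chain.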